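Swapping Bromo for 4-Acetylphenoxy in Compound 3

A few compounds are considered here, and "the series" means these few. Any claim that something is new, unique, unknown or untested is made for them only; others in the source may bear on it.

Measured so far:
Compound 1, `Nc1ccc(C(=O)/C=C/c2ccc(Cl)cc2)cc1`: 58%
Compound 2, `O=C(CBr)Nc1ccc(C(=O)/C=C/c2ccc(Cl)cc2)cc1`: 59%

Both were tested in a functional assay on the whole organism (strain albino) for inhibition, with Rattus norvegicus as the target, read by paw edema, with stated times of 30 min and 4 h, at a dose of 100 mg/kg by the oral route; a higher number here means more inhibition at the dose given (going by the name of the read-out), a lower number less inhibition. Compound 2 carries the higher of the two numbers, yet the gap to compound 1 is within the scatter, so the two compounds are not truly distinguished. Among the compounds with values here, the only measured step, a number 1 percentage points higher from compound 1 to compound 2 (within the scatter), is likewise within the scatter.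

Compound 3 `CC(=O)c1ccc(OCC(=O)Nc2ccc(C(=O)/C=C/c3ccc(Cl)cc3)cc2)cc1` differs from compound 2 in one place: 4-acetylphenoxy in place of bromo on a saturated chain carbon bound to a carbonyl carbon. Within the data shown here, no measured step bears on this change; the sole step known concerns a (bromomethyl)carbonyl in place of hydrogen on a nitrogen on an aromatic ring and says nothing about replacing the bromo itself. Among the measured compounds shown here, with only two near-identical values to go on, no step beyond the scatter is expected in this assay. Compound 3 is therefore estimated at 60%, with a range from 45% to 75%. The expected step is a number 1 percentage points higher from compound 2 to compound 3 (within the scatter).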

Compound 3, a percentage reported as inhibition, in the whole organism at one dose (the size of the read-out at that dose, not a potency): 58%
Estimate against measurement, compound 3: 2 percentage points above, and the stated range covers the measured number.
By their numbers in this assay, from the lowest: compounds 1, 3 and 2 (each within the scatter of the next).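

Putting 4-acetylphenoxy in place of bromo on a saturated chain carbon bound to a carbonyl carbon gives, in this assay, a number 1 percentage points lower from compound 2 to compound 3 (within the scatter). This position therefore carries 10 heavy atoms and an aromatic ring instead of a single bromine with no change in the number beyond the scatter, something the earlier step, made on the nitrogen, could not show. No accompanying measurement speaks to the reason for this result.

With only these two groups at this place, nothing yet shows what could move the number here, so an amine or a carboxylic acid on this chain carbon remains an open case. The read-out also reflects one oral dose, so it leaves open whether compound 2 and compound 3 would stay this close at other doses.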